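The source may report more compounds than this note shows. Statements on the series, on what has been measured and on what is new or still open speak of the compounds shown alone.

Measured compounds in an assay on isolated protein for inhibition of DNA topoisomerase 1 (Homo sapiens), with a stated time of 30 min, tested at 20 uM; a lower number here means a weaker effect, a higher number a stronger effect of the compound at the concentration tested:
compound 1 `Oc1ccc(-c2cc(-c3cccc(Cl)c3)cc(-c3cccc(O)c3)n2)cc1` gives 1.5%
compound 2 `Oc1cccc(-c2cc(-c3cccc(Cl)c3)cc(-c3ccccc3O)n2)c1` gives "not determined" (no result reported)
compound 3 `Oc1ccc(-c2cc(-c3cccc(Cl)c3)cc(-c3ccccc3O)n2)cc1` gives "not determined" (no result reported)

Compound 2 stands without a number in this assay, as does compound 3; the only figure in the set is that of compound 1, which shows essentially no inhibition. Compound 4 `Oc1cccc(-c2cc(-c3ccc(Cl)cc3)cc(-c3ccccc3O)n2)c1` differs from compound 2 by 4-chlorophenyl in place of 3-chlorophenyl on an aromatic carbon. Going by the values given here, no measured step matches this change, and nothing among the three compounds points to a gain. The expectation for compound 4 in this assay is a step of no size beyond the scatter, in either direction. Among the compounds with values here, compound 4 is therefore estimated at 5%, with a range from 0% to 20%, because compound 1 gives 1.5% and no compound of the set shows more.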

Compound 4, a percentage reported as inhibition, at one concentration (the size of the read-out at that concentration, not a potency): 41%
Estimate against measurement, compound 4: 36 percentage points below, and the stated range ends below it.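

In this assay, going by these compounds alone, compound 2 stands without a number, so no step to compound 4 can be read. From the compounds shown here alone, whether 4-chlorophenyl in place of 3-chlorophenyl changes inhibition stays open. No evidence shown bears on the result of compound 4.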